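Fluoro for methoxy on the chain of compound 2

The compounds below may be only part of what the source reports. "The series", "measured", "known", "first", "only" and "open" are said of these compounds alone.

Compound 1 `COc1cc(C(c2ccc(O)c(OC)c2)[C@H](C)C(C)C)ccc1O` gives 16000 nM in a functional assay on HeLa cells (Homo sapiens) for cytotoxicity, read by WST assay, with a stated time of 48 h; on this read-out higher numbers stand for weaker inhibition and lower numbers for stronger inhibition. Compound 2 `COC[C@@H](C)[C@@H](C)C(c1ccc(O)c(OC)c1)c1ccc(O)c(OC)c1` gives > 100000 nM in this assay, and this is a limit of the assay, not a number. Compound 2 therefore has no exact position in the series.

Compound 3 `COc1cc(C(c2ccc(O)c(OC)c2)[C@H](C)[C@H](C)CF)ccc1O` keeps the shared core and differs from compound 2 by fluoro in place of methoxy on a saturated chain carbon, four bonds along the chain from two aromatic carbons.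

Among the measured compounds shown here, only one measured step bears on this change. It is an at least 6.2-fold higher number from compound 1 to compound 2 (0.79 log units; beyond the scatter), which lies beyond the scatter and comes with methoxy in place of hydrogen at that same place. Compound 3 loses that methoxy, but fluoro takes its place rather than the hydrogen of compound 1. A step to a lower number is therefore expected in this assay, of similar size to the measured one or somewhat smaller. The estimated step is an at least 3.3-fold lower number from compound 2 to compound 3 (0.52 log units; beyond the scatter). The estimate for compound 3 is 30000 nM, with an expected range of 10000 nM to 100000 nM.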

Compound 3, half-maximal inhibitory concentration: 75000 nM
Beside the measured number, compound 3's estimate is 2.5-fold (0.40 log units) below it, within the range that was stated.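

In this assay, fluoro in place of hydrogen on a saturated chain carbon, four bonds along the chain from two aromatic carbons, gives a 4.7-fold higher number from compound 1 to compound 3 (0.67 log units; beyond the scatter), so the cost of a group other than hydrogen at this place now has a measured size rather than only a floor. With the step from compound 1 to compound 2 also beyond the scatter, compound 1 remains the strongest of the three, and neither replacement of its hydrogen matches it. Fluoro in place of methoxy gives an at least 1.3-fold lower number from compound 2 to compound 3 (0.12 log units; that floor lies within the scatter), and the true size of this step stays unknown because compound 2 is held at a limit of the assay and not at a number: the limit of > 100000 nM in this assay, at which 1 of the 3 values shown sits.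

The compounds shown leave open whether any group at this place other than hydrogen can keep the level of compound 1, for instance a hydroxyl, an amine, a carboxylic acid or a longer chain. Also open, as far as these compounds go, is whether the order of these three compounds holds in any cell line other than the one used here, since all of the values come from a single read-out.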